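Fluoro for Methyl on the Central Ring of Compound 3

The compounds below may be only part of what the source reports. "The series", "measured", "known", "first", "only" and "open" are said of these compounds alone.

Compound 1 `Cc1ccccc1COc1ccc(-c2cc(CN3CCN(Cc4ccc(C(F)(F)F)cc4)CC3)no2)cc1` and compound 2 `Fc1ccccc1COc1ccc(-c2cc(CN3CCN(Cc4ccc(C(F)(F)F)cc4)CC3)no2)cc1` differ by fluoro in place of methyl on an aromatic carbon. In a functional assay on MCF7 cells (Homo sapiens) for antiproliferative activity, read by sulforhodamine B assay, with a stated time of 72 h (on this read-out higher numbers stand for weaker inhibition and lower numbers for stronger inhibition), compound 1 gives 3700 nM, and compound 2 gives 3000 nM, a step of a 1.2-fold lower number from compound 1 to compound 2 (0.09 log units; within the scatter). Compound 3 `Cc1cc(-c2cc(CN3CCN(Cc4ccc(C(F)(F)F)cc4)CC3)no2)ccc1OCc1cccc(C#N)c1` gives 700 nM in this assay; how its core differs from that of compound 1 is not broken down here. Compound 4 `N#Cc1cccc(COc2ccc(-c3cc(CN4CCN(Cc5ccc(C(F)(F)F)cc5)CC4)no3)cc2F)c1` has not been measured; it differs from compound 3 by fluoro in place of methyl on an aromatic carbon. This is the same kind of change as that from compound 1 to compound 2, but the place differs: in compound 3 it is ortho to a (3-cyanobenzyl)oxy group and meta to a large group, while in compound 1 it is ortho to a large group. Because the step of a 1.2-fold lower number from compound 1 to compound 2 (0.09 log units; within the scatter) lies within the scatter, a similarly small step is expected here, a 1.2-fold lower number from compound 3 to compound 4 (0.07 log units; within the scatter). Compound 4 is therefore estimated at 600 nM, with a likely range from 280 nM to 1300 nM.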

Compound 4, half-maximal inhibitory concentration: 380 nM
Compound 4: the middle estimate sits 1.6-fold (0.20 log units) above what was measured; low and high end bracket the measured number.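

In this assay fluoro in place of methyl gives a 1.8-fold lower number from compound 3 to compound 4 (0.27 log units; within the scatter) and does not stand apart from the step on the core of compound 1: the same change on two cores in this assay, a 1.2-fold lower number (0.09 log units; within the scatter) from compound 1 to compound 2 and a 1.8-fold lower number (0.27 log units; within the scatter) from compound 3 to compound 4, 1.5-fold (0.17 log units) apart, within the scatter of two such steps.
On these two cores, then, the change carries over as a small step, and the two steps cannot be told apart. Within the data shown here, this rests on only two pairs, with the change in a different place on each, so it does not show how the change would behave on any further core.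

The compounds shown leave open whether a chloro or methoxy group, ortho to a (3-cyanobenzyl)oxy group, would give a similar step. They also leave open what an amine or a carboxylic acid in that place would do.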